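Removing One Methoxy Group: What to Expect

The source may report more compounds than this note shows. Statements on the series, on what has been measured and on what is new or still open speak of the compounds shown alone.

Compound 1 `Nc1ccc(C(=O)/C=C/c2ccc(O)c(F)c2)cc1-c1ccc(F)cc1` gives 31700 nM in a functional assay on SW480 cells (Homo sapiens) for cytotoxicity, read by sulforhodamine B assay, with a stated time of 48 h; on this read-out higher numbers stand for weaker inhibition and lower numbers for stronger inhibition.
Compound 2 `COc1ccc(/C=C/C(=O)c2ccc(N)c(-c3ccc(F)cc3)c2)cc1OC` gives 6640 nM in this assay.
Compound 3 `COc1ccc(/C=C/C(=O)c2cccc(-c3ccc(F)cc3)c2)cc1OC` gives 6490 nM in this assay.

Compound 2 stands second highest of the three numbers. Its nearest neighbour is compound 3: a 1.0-fold lower number from compound 2 to compound 3 (0.01 log units; within the scatter). Compound 1 is furthest away, with the highest number of the three, a gap beyond the scatter.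

Compound 4 `COc1ccc(/C=C/C(=O)c2ccc(N)c(-c3ccc(F)cc3)c2)cc1` differs from compound 2 in one place: hydrogen in place of methoxy on an aromatic carbon. Within the data shown here, no measured step removes a methoxy group, so none bears on this change directly; the one step available, from compound 2 to compound 3, concerned a different group and stayed within the scatter. With no direct guide, no step beyond the scatter in this assay is expected. Compound 4 is therefore estimated at 7000 nM, with a range from 3000 nM to 16000 nM. This estimate means an expected step of a 1.1-fold higher number from compound 2 to compound 4 (0.02 log units; within the scatter).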

Compound 4, half-maximal inhibitory concentration: 7230 nM
Beside the measured number, compound 4's estimate is 1.0-fold (0.01 log units) below it; the measured number falls inside the stated range.
By their numbers in this assay, from the lowest: compounds 3, 2 and 4 (each within the scatter of the next); then compound 1.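

In this assay, putting hydrogen in place of this methoxy gives a 1.1-fold higher number from compound 2 to compound 4 (0.04 log units; within the scatter), so on this carbon, ortho to a methoxy group, the group can go without a change that stands clear of the scatter. A wider change to the same ring does show up: 4-methoxyphenyl in place of 3-fluoro-4-hydroxyphenyl gives a 4.4-fold lower number from compound 1 to compound 4 (0.64 log units; beyond the scatter), a modest step beyond the scatter. No measurement here explains either step.

Going by these compounds, whether an ethoxy group or a chlorine atom on this carbon would also stay within the scatter remains open. So does the effect of taking away the remaining methoxy.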